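The source may report more compounds than this note shows. Statements on the series, on what has been measured and on what is new or still open speak of the compounds shown alone.

Measured compounds:
compound 1 `Cc1cc2nc(-c3cc(Cl)cc(Br)c3O)[nH]c2cc1C` with 2920 nM
compound 2 `Cc1cc2nc(-c3cc(Cl)cc(Cl)c3O)[nH]c2cc1C` with 2980 nM
compound 3 `Oc1c(Cl)cc(Cl)cc1-c1nc2cc(F)ccc2[nH]1` with 2870 nM

The three measured compounds were tested in an assay for inhibition of Alpha amylase (Homo sapiens), with a stated time of 10 min; a lower number here means a stronger inhibitor, a higher number a weaker inhibitor. Compound 2 gives 2980 nM and compound 1 gives 2920 nM; the step between them, a 1.0-fold lower number from compound 2 to compound 1 (0.01 log units; within the scatter), is bromo in place of chloro on an aromatic carbon. Compound 3 stands on a different core; the difference between the two cores is not broken down here. In this assay compound 3 gives 2870 nM, and all three values lie within the scatter of one another.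

Compound 4 `Oc1c(Br)cc(Cl)cc1-c1nc2cc(F)ccc2[nH]1` has not yet been measured. It differs from compound 3 by bromo in place of chloro on an aromatic carbon, the same change as that from compound 2 to compound 1, made at a place described in the same words. Because that earlier step was a 1.0-fold lower number from compound 2 to compound 1 (0.01 log units; within the scatter), the account expects the step from compound 3 to compound 4 to be equally small, estimated as a 1.0-fold higher number from compound 3 to compound 4 (0.00 log units; within the scatter). The estimate for compound 4 in this assay is therefore 2900 nM, expected to fall between 1500 nM and 5600 nM. The measurement will show whether this holds.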

Compound 4, half-maximal inhibitory concentration: 2860 nM
Beside the measured number, compound 4's estimate is 1.0-fold (0.01 log units) above it; measured number inside the range.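

On the core of compound 3, bromo in place of chloro on an aromatic carbon, ortho to a hydroxy group, gives a 1.0-fold lower number from compound 3 to compound 4 (0.00 log units; within the scatter) in this assay. Set beside the earlier step, the same change on the other core shows no difference between the two cores: the same change on two cores in this assay, a 1.0-fold lower number (0.01 log units; within the scatter) from compound 2 to compound 1 and a 1.0-fold lower number (0.00 log units; within the scatter) from compound 3 to compound 4, 1.0-fold (0.01 log units) apart, within the scatter of two such steps This shows that the exchange leaves the number within the scatter on both cores, but with so small a step on each, it does not show that the two cores would respond alike to a change with a larger effect, nor that the exchange would be as small on any other core.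

All the compounds shown carry either chloro or bromo at this place, which leaves open what an amine, a carboxylic acid or a longer chain would do there. Every compound shown also keeps the hydroxy group, and what a methoxy group in its stead would do to the number in this assay remains open.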